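The source may hold more compounds than are shown below. What is called first, only, known or untested is meant among the compounds shown, and "the series" means these compounds.

Measured compounds:
- compound 1, `CC(N)c1nnc(-c2ccccc2-c2ccccc2)s1`: in a functional assay on the whole organism with Mus musculus as the target (a higher number here means that more compound is needed for the effect, a lower number that less compound is needed), compound 1 gives 21 mg/kg
- compound 2, `CNCc1nnc(-c2ccccc2-c2ccccc2)s1`: compound 2 gives 25 mg/kg
- compound 3, `CNCc1nnc(-c2ccccc2)s1`: compound 3 gives only a limit in this assay, > 200 mg/kg

Compound 2 stands highest of the two plain numbers, with compound 1 nearest: the step of a 1.2-fold higher number from compound 1 to compound 2 (0.08 log units; within the scatter) is within scatter, so the two cannot be told apart. The value of compound 3 is a limit, not a number. The step of an at least 8.0-fold higher number from compound 2 to compound 3 (0.90 log units; beyond the scatter) is the only one beyond scatter, and it removes a phenyl from the shared core of compound 2.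

Compound 4 is `c1ccc(CNCc2nnc(-c3ccccc3-c3ccccc3)s2)cc1`. Its difference from compound 2 is phenyl in place of hydrogen on a saturated chain carbon bound to an amine nitrogen. Among the compounds with values here, the measured steps touch the amine side chain only once, in the step from compound 1 to compound 2, which stayed within scatter; no measured step adds a phenyl on this chain, so there is no direct precedent. Because the step of a 1.2-fold higher number from compound 1 to compound 2 (0.08 log units; within the scatter) shows the amine side chain tolerating a small change, the expectation for compound 4 is a step of a 1.2-fold higher number from compound 2 to compound 4 (0.08 log units; within the scatter) not beyond scatter. Compound 4 is therefore estimated at 30 mg/kg, with a range from 12 mg/kg to 80 mg/kg.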

Compound 4, dose for half-maximal effect: 37 mg/kg
For compound 4 the middle estimate is 1.2-fold (0.09 log units) below the measured one; low and high end bracket the measured number.
By their numbers in this assay, from the lowest: compounds 1, 2 and 4 (each within the scatter of the next). At a limit, above all of these: compound 3.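

In this assay, within the data shown here, a far larger group is accepted on the amine side chain than the earlier compounds could show, as phenyl in place of hydrogen on a saturated chain carbon bound to an amine nitrogen gives a 1.5-fold higher number from compound 2 to compound 4 (0.17 log units; within the scatter). Among these compounds, until now the only change on this side chain was a swap of small groups, a 1.2-fold higher number from compound 1 to compound 2 (0.08 log units; within the scatter), so nothing yet showed that methylamino could give way to benzylamino while the number stayed within the scatter. The added phenyl also stands in contrast to the phenyl on the shared core, whose loss gives an at least 8.0-fold higher number from compound 2 to compound 3 (0.90 log units; beyond the scatter), so in these compounds the same group counts for much in one place and for little in the other.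

From the compounds shown here alone, how far this tolerance reaches stays open, for example with a longer chain such as phenylpropyl, or with a carboxylic acid in place of the phenyl. Nothing shown here bears on why the added phenyl leaves the number within the scatter.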